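Adding a Second Trifluoromethyl on a Related Amide Core

The source may hold more compounds than are shown below. What is called first, only, known or untested is meant among the compounds shown, and "the series" means these compounds.

Measured compounds:
compound 1, `Cc1cc(NC(=O)c2cccc(C(F)(F)F)c2)ccc1NS(=O)(=O)C(F)(F)F`: 8720 nM
compound 2, `Cc1cc(NC(=O)c2cc(C(F)(F)F)cc(C(F)(F)F)c2)ccc1NS(=O)(=O)C(F)(F)F`: 40700 nM
compound 3, `COc1cc(NC(=O)c2cccc(C(F)(F)F)c2)ccc1NS(C)(=O)=O`: 84800 nM

Of the compounds shown here, three have been tested in an ADME assay on RAW264.7 cells (Mus musculus) for cytotoxicity, read by MTT assay, with a stated time of 48 h; a higher number here means a weaker inhibitor, a lower number a stronger inhibitor. Compound 1 gives 8720 nM in this assay. Compound 2 differs from compound 1 by one change, (trifluoromethyl in place of hydrogen on an aromatic carbon), and this change produced a 4.7-fold higher number from compound 1 to compound 2 (0.67 log units; beyond the scatter). Compound 3 is built on a different core; how its core differs from that of compound 1 is not broken down here. In this assay compound 3 gives 84800 nM, the highest of the three numbers, so it is the weakest inhibitor among them.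

Compound 4, `COc1cc(NC(=O)c2cc(C(F)(F)F)cc(C(F)(F)F)c2)ccc1NS(C)(=O)=O`, has not yet been measured. It differs from compound 3 by trifluoromethyl in place of hydrogen on an aromatic carbon. Within the data shown here, this is the same change as the one from compound 1 to compound 2, and the surroundings of the place where it happens are described in the same words for both pairs. Among the measured compounds shown here, the only guide to its size is the earlier pair: because the step of a 4.7-fold higher number from compound 1 to compound 2 (0.67 log units; beyond the scatter) was a modest rise, a rise of similar size is expected here, namely a 4.1-fold higher number from compound 3 to compound 4 (0.62 log units; beyond the scatter). Since compound 3 already stands high, the number for compound 4 is expected to be 350000 nM, most likely between 130000 nM and 900000 nM, and there is a real chance that such a high value is reported only as a limit.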

Compound 4, half-maximal inhibitory concentration: > 250000 nM
Compound 4: no number, only a limit; the forecaster's own chance of this, stated with the estimate: 40%; the middle value is on the limit's open side.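

In this assay compound 4 is reported as > 250000 nM, which is a limit of the assay and not a number. Placing trifluoromethyl where hydrogen stood gives an at least 2.9-fold higher number from compound 3 to compound 4 (0.46 log units; beyond the scatter), so the number rises on this core, as it did on the core of compound 1 with a 4.7-fold higher number from compound 1 to compound 2 (0.67 log units; beyond the scatter), and in both pairs the compound with the added group is the weaker inhibitor in this assay. The direction of the change therefore carries across these two cores, but two pairs are a small basis for a rule, and whether the size of the step also carries across remains unsettled: the same change on two cores in this assay, a 4.7-fold higher number (0.67 log units; beyond the scatter) from compound 1 to compound 2 and an at least 2.9-fold higher number (0.46 log units; beyond the scatter) from compound 3 to compound 4; the limit leaves it open whether they differ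

The compounds shown leave open whether a smaller group at the same place, such as a fluorine atom, a chlorine atom, a methyl or a nitrile, would raise the number in the same way as trifluoromethyl. They also leave open which part of the core matters for the size of the step, and no pair shown links the core of compound 1 to the core of compound 3 through a single change.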